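The compounds below may be only part of what the source reports. "The series", "measured", "known", "first", "only" and "open" are said of these compounds alone.

In an ADME assay on the whole organism (plasma, Mus musculus, strain CD-1) for protein binding, read by LC-MS, with a stated time of 24 h (a lower number here means a smaller unbound share, a higher number a larger unbound share of the compound), compound 2 `Cc1noc(-c2ccc(O[C@H]3CCC[C@H](C(=O)O)C3)cc2)c1COC(=O)N(C)C1CCCC1` gives 0.006, the lowest of the three numbers in hand. Compound 3 `Cc1nc(-c2nnn(C)c2COC(=O)N(C)CC2CCC2)cnc1O[C@H]1CCC[C@H](C(=O)O)C1` gives 0.073, a gap that lies beyond the scatter, and compound 1 `CCCCN(C)C(=O)OCc1c(-c2ccc(O[C@H]3CCC[C@H](C(=O)O)C3)c(C)n2)nnn1C` gives 0.134, further away still. Compound 4 `Cc1noc(-c2ccc(O[C@H]3CCC[C@H](C(=O)O)C3)cc2)c1COC(=O)N(C)CCC(C)C` has not been measured; it differs from compound 2 in a single place: isopentyl in place of cyclopentyl on an amide-type nitrogen. Among the measured compounds shown here, no pair of measured compounds shows what an exchange of this kind does, and the group that leaves and the group that enters are counted alike under that difference. Compound 4 is expected to stay close to compound 2, with a step of a 1.3-fold higher number from compound 2 to compound 4 (0.12 log units; within the scatter) that does not go beyond the scatter. The estimate for compound 4 is 0.008, in a range from 0.003 to 0.02.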

Compound 4, unbound fraction: 0.004
For compound 4 the middle estimate is 2.0-fold (0.30 log units) above the measured one; the measured number falls inside the stated range.
By their numbers in this assay, from the lowest: compounds 4 and 2 (each within the scatter of the next); then compounds 3 and 1 (each within the scatter of the next).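

In this assay, isopentyl in place of cyclopentyl on the amide-type nitrogen gives a 1.5-fold lower number from compound 2 to compound 4 (0.18 log units; within the scatter). Among the compounds shown here, this is the first single-place step, and it shows that on this core an open chain can replace the carbon ring, with the same count of heavy atoms, without a step beyond the scatter. Nothing available explains this result.

The compounds shown leave open whether an amine or a carboxylic acid on this chain, or a longer chain, would stay as close. They also leave open whether the same exchange would behave alike on the core of compound 1 or compound 3.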